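This account rests on a few compounds, and the source may have more. Where it says the series, first, only, none or still open, it means among the compounds named here.

Measured compounds:
- compound 1, `CN(C)CCCCCSC1=Nc2ccccc2C(CC(=O)NCc2ccccc2)N1c1ccc(-c2ccc(F)cc2)cc1`: in an assay on cells for inhibition of Voltage-dependent T-type calcium channel subunit alpha-1H (Homo sapiens), read by patch clamp (on this read-out higher numbers stand for weaker inhibition and lower numbers for stronger inhibition), compound 1 gives 4180 nM
- compound 2, `CN(C)CCCCCSC1=Nc2ccccc2C(CC(=O)NCc2ccccc2)N1c1ccccc1`: in this assay compound 2 gives 13800 nM
- compound 3, `CN(C)CCCCCSC1=Nc2ccccc2C(CC(=O)NCc2ccccc2)N1c1ccc(-c2ccccc2)cc1`: in this assay compound 3 gives 2400 nM

Among these three, compound 3 has the lowest number. Its nearest neighbour is compound 1, and the step of a 1.7-fold lower number from compound 1 to compound 3 (0.24 log units; within the scatter) stays within the usual scatter, so the two cannot be ranked against each other. The step of a 5.8-fold lower number from compound 2 to compound 3 (0.76 log units; beyond the scatter) lies beyond the scatter, as does a 3.3-fold higher number from compound 1 to compound 2 (0.52 log units; beyond the scatter).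

Compound 4, `O=C(CC1c2ccccc2N=C(SCCCCCN2CCCC2)N1c1ccc(-c2ccccc2)cc1)NCc1ccccc1`, has not yet been measured. It differs from compound 3 in one place: pyrrolidin-1-yl in place of dimethylamino on a saturated chain carbon, five bonds along the chain from a sulfur. The shared core, the chain and the aromatic groups are unchanged.

All three measured steps concern the group on the aromatic ring; none of them touches the amine at the end of the chain. Within the data shown here, nothing among the measured compounds therefore speaks for or against this change, and the expectation rests only on the closeness of the two amines, which agree in their counted donors and acceptors. The expected step of no change at the digits printed from compound 3 to compound 4 (within the scatter) is therefore none beyond the scatter. Compound 4 is estimated at 2400 nM in this assay, with a range from 1000 nM to 6000 nM.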

Compound 4, half-maximal inhibitory concentration: 6900 nM
Beside the measured number, compound 4's estimate is 2.9-fold (0.46 log units) below it; measured number outside the range, above it.
By their numbers in this assay, from the lowest: compounds 3, 1, 4 and 2 (each within the scatter of the next, the first and the last beyond it).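

The amine at the end of the chain is not a silent part of these molecules: in this assay, pyrrolidin-1-yl in place of dimethylamino gives a 2.9-fold higher number from compound 3 to compound 4 (0.46 log units; beyond the scatter), so inhibition is weaker with the ring. The two groups agree in their counted hydrogen-bond donors and acceptors and neither carries a net charge, so those counts alone do not predict the outcome at this position. Among these compounds, the earlier steps all concerned the group on the aromatic ring, and this is the first sign that the far end of the chain also affects the number, though nothing measured here explains why.

A single pair of amines cannot show whether the drop follows from closing the ring or from the added carbons, and diethylamino, piperidin-1-yl or morpholin-4-yl in the same place would help to separate these. Going by these compounds, it also remains open whether pyrrolidin-1-yl has the same effect with the 4-fluorophenyl group or with hydrogen on the aromatic ring, or on a shorter or longer chain.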